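A few compounds are considered here, and "the series" means these few. Any claim that something is new, unique, unknown or untested is made for them only; others in the source may bear on it.

Among the compounds with values here, compound 2 `N#Cc1ccc(N2CCN(C(=S)SCc3ccc(C(=O)Nc4ccccc4N)cc3)CC2)cc1` gives 71.6% in a functional assay on HeLa cells (Homo sapiens) for antiproliferative activity, read by CCK-8 assay, with a stated time of 72 h, tested at 2 uM (on this read-out lower numbers stand for a weaker effect and higher numbers for a stronger effect at the one concentration tested), the highest of the three numbers known here. Compound 3 `CN(Cc1ccncc1)C(=S)SCc1ccc(C(=O)Nc2ccccc2N)cc1` gives 29.5%, and compound 1 `Nc1ccccc1NC(=O)c1ccc(CSC(=S)N2CCCc3ccccc32)cc1` gives 26.1%; the gap from either of them to compound 2 lies beyond the scatter. Compound 4 `Nc1ccccc1NC(=O)c1ccc(CSC(=S)N2CCN(c3ccncc3)CC2)cc1` differs from compound 2 in one place: pyridin-4-yl in place of 4-cyanophenyl on an amine nitrogen in a ring. Within the data shown here, the only measured step, a number 3.4 percentage points higher from compound 1 to compound 3 (within the scatter), changes the amine on the thiocarbonyl carbon rather than the group on the amine nitrogen of the six-membered non-aromatic ring with 2 nitrogen, so it does not bear directly on the change to compound 4. What the numbers do show is that compound 3, whose methyl((pyridin-4-yl)methyl)amino group carries a pyridine, sits far below compound 2. Among the measured compounds shown here, no step tells how much of the number for compound 2 rests on the 4-cyanophenyl group. A change of a number 16.6 percentage points lower from compound 2 to compound 4 (beyond the scatter) is expected, a loss of moderate size with wide uncertainty. Compound 4 is thus estimated at 55%, expected between 30% and 75%.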

Compound 4, a percentage reported as inhibition, at one concentration (the size of the read-out at that concentration, not a potency): 77%
Beside the measured number, compound 4's estimate is 22 percentage points below it, and the stated range ends below it.
By their numbers in this assay, from the lowest: compounds 1 and 3 (each within the scatter of the next); then compounds 2 and 4 (each within the scatter of the next).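

In this assay, pyridin-4-yl in place of 4-cyanophenyl on an amine nitrogen in a ring gives a number 5.4 percentage points higher from compound 2 to compound 4 (within the scatter), the first step measured at this position. Within these two compounds, the nitrile and the carbon-only aromatic ring are therefore not required for a number at this level, as a six-membered aromatic ring with 1 hetero atom serves as well within the scatter. No measured evidence here bears on why the two groups read alike.

The compounds shown leave open how a plain phenyl, a methyl or an acetyl group on this amine nitrogen would read, and so whether an aromatic ring is needed there at all. Within the data shown here, they also leave open whether the six-membered non-aromatic ring with 2 nitrogen itself matters, as no step links compound 2 or compound 4 to compound 1 or compound 3.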